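The source may hold more compounds than are shown below. What is called first, only, known or untested is meant among the compounds shown, and "the series" means these compounds.

Three compounds have been measured in a functional assay on SNU-423 cells (Homo sapiens) for inhibition, read by MTT assay, with a stated time of 72 h; a lower number here means a stronger inhibitor, a higher number a weaker inhibitor:

Compound 1 `CNC(=O)CCCCCCCn1nc(-c2ccc3oc(N)nc3c2)c2c(N)ncnc21` — 280 nM
Compound 2 `Nc1nc2cc(-c3nn(CCCCCCCCCC(=O)NO)c4ncnc(N)c34)ccc2o1` — > 50000 nM, which is a limit of the assay and not a number the limit of > 50000 nM in this assay, at which 1 of the 3 values shown sits.
Compound 3 `Nc1nc2cc(-c3nn(CCCCCCCCC(=O)NO)c4ncnc(N)c34)ccc2o1` — 4940 nM

Compound 3 therefore stands highest of the two numbers shown; its nearest neighbour is compound 1, and the gap is an 18-fold higher number from compound 1 to compound 3 (1.25 log units; beyond the scatter), which is beyond the scatter.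

Compound 4 `Nc1nc2cc(-c3nn(CCCCCCC(=O)NO)c4ncnc(N)c34)ccc2o1` has not yet been measured in this assay. Its difference from compound 3 is hydroxycarbamoyl in place of 2-(hydroxycarbamoyl)ethyl on a saturated chain carbon, six bonds along the chain from an aromatic nitrogen. In plain terms, the chain that carries the hydroxycarbamoyl end is cut shorter by two carbons.

Among the compounds with values here, one measured step bears on this kind of change: the step of an at least 10-fold lower number from compound 2 to compound 3 (1.00 log units; beyond the scatter), where the same chain was shortened by a single carbon and the number fell. Compound 4 shortens it by two more. Within the data shown here, on that evidence a further fall in the number is expected, in the direction of a stronger inhibitor, though with only one step to rest on its size is uncertain. The expected step is a 4.9-fold lower number from compound 3 to compound 4 (0.69 log units; beyond the scatter). Compound 4 is estimated to give 1000 nM in this assay, with a plausible range from 150 nM to 6000 nM.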

Compound 4, half-maximal inhibitory concentration: 6100 nM
Beside the measured number, compound 4's estimate is 6.1-fold (0.79 log units) below it; the whole stated range lies below it.
By their numbers in this assay, from the lowest: compound 1; then compounds 3 and 4 (each within the scatter of the next). At a limit, above all of these: compound 2.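

Removing two carbons from the chain that carries the hydroxycarbamoyl end makes no difference that can be read in this assay, a 1.2-fold higher number from compound 3 to compound 4 (0.09 log units; within the scatter), so the clear effect of chain length seen at the longest chain does not carry on through this shorter pair. The longest chain still stands apart, an at least 8.1-fold lower number from compound 2 to compound 4 (0.91 log units; beyond the scatter), while shortening the chain does nothing to close the gap to the methylcarbamoyl chain, a 22-fold higher number from compound 1 to compound 4 (1.34 log units; beyond the scatter), which shows that within this set the identity of the chain end counts for more than these last two carbons. Compound 2 carries a limit of the assay and not a number: the limit of > 50000 nM in this assay, at which 1 of the 4 values shown sits.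

The compounds shown leave open whether a hydroxycarbamoyl chain shorter still would stay level with these two or move clear of them. They also leave open how a carboxylic acid or an unsubstituted amide at the end of the same chain would compare with the methylcarbamoyl end, and whether the methylcarbamoyl end itself depends on chain length.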